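The source may report more compounds than this note shows. Statements on the series, on what has been measured and on what is new or still open speak of the compounds shown alone.

Compound 3 `N/C(=N\NC(=S)N1CCCCC1)c1ccccn1` gives 27% in a functional assay on A-431 cells (Homo sapiens) for cytotoxicity, read by MTT assay, with a stated time of 72 h, tested at 3 uM (on this read-out lower numbers stand for less inhibition of growth and higher numbers for more inhibition of growth at the one concentration tested), the lowest of the three measured numbers: compound 1 `N/C(=N\NC(=S)N1CCOCC1)c1ccccn1` gives 43.1% and compound 2 `N/C(=N\NC(=S)N1CCSCC1)c1ccccn1` gives 37.2%. The steps of a number 16.1 percentage points lower from compound 1 to compound 3 (beyond the scatter) and a number 10.2 percentage points lower from compound 2 to compound 3 (beyond the scatter) lie beyond the scatter, while a number 5.9 percentage points lower from compound 1 to compound 2 (within the scatter) lies within it. Compound 4 `Cc1cccc(/C(N)=N/NC(=S)N2CCCCC2)n1` differs from compound 3 by methyl in place of hydrogen on an aromatic carbon. For the measured compounds named here, none of the measured steps concerns this ring; all three exchange the ring on the thiocarbonyl carbon, so no measured step bears directly on this change. The expected step of no change at the digits printed from compound 3 to compound 4 (within the scatter) is therefore small, with no change beyond the scatter expected. The estimate for compound 4 is 27%, within 12% to 42%.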

Compound 4, percent growth inhibition at one concentration: 36.6%
Compound 4: middle estimate off by 9.6 percentage points, on the low side; measured number inside the range.
By their numbers in this assay, from the lowest: compounds 3, 4, 2 and 1 (each within the scatter of the next, the first and the last beyond it).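

In this assay, methyl in place of hydrogen on an aromatic carbon next to the ring nitrogen gives a number 9.6 percentage points higher from compound 3 to compound 4 (within the scatter). For the compounds shown here, this is the first measured step on the aromatic ring, as the earlier steps all exchanged the ring on the thiocarbonyl carbon, and it shows that this position can carry a methyl without a difference beyond the scatter. Nothing measured here speaks to what lies behind this result.

On these data alone, it remains open whether an amine, a methoxy group or a longer chain at this carbon would give a similar number. As far as these compounds go, it is also open whether methyl would behave the same way with morpholin-4-yl on the thiocarbonyl carbon.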